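A few compounds are considered here, and "the series" means these few. Any claim that something is new, unique, unknown or untested is made for them only; others in the source may bear on it.

Compound 3 `Oc1ccc(-c2cc(-c3cccc(O)c3)cc(-c3cccc(O)c3)n2)cc1` sits at the bottom of the small set: in an assay on isolated protein for inhibition of DNA topoisomerase 1 (Homo sapiens), with a stated time of 30 min, tested at 100 uM (a higher number here means more inhibition at the concentration tested (going by the name of the read-out), a lower number less inhibition), compound 3 gives 0%, and compound 1 `Oc1ccc(-c2cc(-c3ccccc3O)cc(-c3cccc(O)c3)n2)cc1` gives 0%, the two level with each other, while compound 2 `Oc1ccc(-c2cc(-c3ccc(O)cc3)nc(-c3ccc(O)cc3)c2)cc1` gives 3.8%, a gap that stays within the scatter. Compound 4 `Oc1ccc(-c2cc(-c3cccc(O)c3)cc(-c3ccc(O)cc3)n2)cc1` is obtained from compound 3 by the change (4-hydroxyphenyl in place of 3-hydroxyphenyl on an aromatic carbon). For the measured compounds named here, the one measured step that bears on this, no change at the digits printed from compound 1 to compound 3 (within the scatter), exchanged one hydroxyphenyl isomer for another and left the read-out unchanged. Compound 2 and compound 3 also differ by a hydroxyphenyl exchange, and their two values lie together. The step of a number 1 percentage points higher from compound 3 to compound 4 (within the scatter) is therefore expected to be nothing beyond the scatter. Compound 4 is estimated at 1%, in the range 0% to 8%.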

Compound 4, a percentage reported as inhibition, at one concentration (the size of the read-out at that concentration, not a potency): 0%
Compound 4: middle estimate off by 1 percentage points, on the high side; low and high end bracket the measured number.
By their numbers in this assay, from the lowest: compounds 1, 3, 4 and 2 (each within the scatter of the next).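

At the aromatic carbon next to the ring nitrogen, the exchange of 3-hydroxyphenyl for 4-hydroxyphenyl gives no change at the digits printed from compound 3 to compound 4 (within the scatter) in this assay, so this position now shows the same flat read-out as the earlier exchange. The second step, on another aromatic carbon, gives a number 3.8 percentage points lower from compound 2 to compound 4 (within the scatter), so neither hydroxyl placement separates these compounds. No supporting data bear on why the read-out stays flat. The compounds shown leave open whether any other group at these positions, such as an amine or a carboxylic acid, would give a read-out beyond the scatter.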